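The source may report more compounds than this note shows. Statements on the series, on what has been measured and on what is new or still open speak of the compounds shown alone.

Measured compounds:
compound 1 `O=C(O)c1ccccc1-c1ccc(CCc2ncc(C3CCCCC3)[nH]2)cc1` gives 14.7 nM in an in vitro functional assay on cells for agonist activity at Bombesin receptor subtype-3 (Mus musculus), read by luminescence and calcium flux; on this read-out higher numbers stand for an effect only at larger amounts of compound and lower numbers for an effect already at smaller amounts;
compound 2 `CC(C)CCc1cnc(CCc2ccc(-c3ccccc3C(=O)O)cc2)[nH]1` gives 10 nM in this assay.

Compound 2 carries the smaller number of the two, but the step of a 1.5-fold lower number from compound 1 to compound 2 (0.17 log units; within the scatter) lies within the scatter, so neither compound can be set ahead of the other. Compound 3 `O=C(O)c1ccccc1-c1ccc(CCc2ncc(Cc3cccc(F)c3F)[nH]2)cc1` differs from compound 2 by 2,3-difluorophenyl in place of isobutyl on a saturated chain carbon bound to an aromatic carbon. Among the compounds with values here, the single measured step, a 1.5-fold lower number from compound 1 to compound 2 (0.17 log units; within the scatter), swapped one saturated group for another at this position and changed little; no measured step replaces such a group with an aromatic ring, so the direction is open and the range wide. Compound 3 is therefore expected to give 15 nM, within 3 nM to 100 nM. This amounts to an expected step of a 1.5-fold higher number from compound 2 to compound 3 (0.18 log units; within the scatter).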

Compound 3, half-maximal effective concentration: 8 nM
Beside the measured number, compound 3's estimate is 1.9-fold (0.27 log units) above it; the range from low to high includes it.
By their numbers in this assay, from the lowest: compounds 3, 2 and 1 (each within the scatter of the next).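

An aromatic ring can stand at this position, carried as 2,3-difluorobenzyl, and the number stays within the scatter of both saturated groups (a 1.3-fold lower number from compound 2 to compound 3 (0.10 log units; within the scatter)) (a 1.8-fold lower number from compound 1 to compound 3 (0.26 log units; within the scatter)). This place therefore accepts isopentyl, cyclohexyl and 2,3-difluorobenzyl alike, and the numbers give no ranking among them. No measured evidence bears on why this is so.

Open, on these data alone, is whether the two fluorine atoms matter, as a plain benzyl would show. Also open, as far as these compounds go, is what an amine or an amide at this position would do to the number.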